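Swapping the aryl group on the sulfur: compound 2 to compound 3

A few compounds are considered here, and "the series" means these few. Any claim that something is new, unique, unknown or untested is made for them only; others in the source may bear on it.

Measured so far:
compound 1 `CC(Sc1nc2c(cnn2C)c(=O)n1-c1ccccc1)c1ccccn1` — 89 nM
compound 2 `CCC(Sc1nc2c(cnn2C)c(=O)n1-c1ccccc1)c1ccccc1` — 119 nM

Both compounds share one core and differ only in the group attached to the sulfur. In an assay on isolated protein for inhibition of Retinaldehyde dehydrogenase 3 (Homo sapiens) (a higher number here means a weaker inhibitor, a lower number a stronger inhibitor), compound 1 gives 89 nM, and compound 2 gives 119 nM. Going by the values given here, the step from the first to the second, a 1.3-fold higher number from compound 1 to compound 2 (0.13 log units; within the scatter), is the only measured step, and it lies within the scatter. On the numbers shown, compound 2 stands highest of the two, with compound 1 close by.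

Compound 3 `CC(Sc1nc2c(cnn2C)c(=O)n1-c1ccccc1)c1cccc(F)c1` keeps the same core and again changes only the group on the sulfur: 1-(3-fluorophenyl)ethyl in place of 1-phenylpropyl on a sulfur. Among the compounds with values here, the one measured step at this position, from a pyridine-bearing chain to a phenyl-bearing one, barely moved the number, so the sulfur substituent appears tolerant of such swaps, though only two compounds support this. For compound 3, the step of a 1.2-fold lower number from compound 2 to compound 3 (0.08 log units; within the scatter) is therefore expected to stay within the scatter. The estimate for compound 3 in this assay is 100 nM, with a likely range from 40 nM to 300 nM.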

Compound 3, half-maximal inhibitory concentration: 128 nM
Compound 3: middle estimate off by 1.3-fold (0.11 log units), on the low side, and the stated range covers the measured number.
By their numbers in this assay, from the lowest: compounds 1, 2 and 3 (each within the scatter of the next).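

In this assay, three different groups on the sulfur can now be compared, and all the steps between them lie within the scatter. Putting 1-(3-fluorophenyl)ethyl in place of 1-phenylpropyl gives a 1.1-fold higher number from compound 2 to compound 3 (0.03 log units; within the scatter), while putting 3-fluorophenyl in place of pyridin-2-yl on the chain gives a 1.4-fold higher number from compound 1 to compound 3 (0.16 log units; within the scatter), so neither change separates these compounds in this assay. No available evidence accounts for this flat result. The compounds shown leave open whether a different kind of group on this chain, such as an amine or a carboxylic acid, would shift the number beyond the scatter. They also leave open whether a longer chain, such as 1-phenylpentyl, would do so.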